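The compounds below may be only part of what the source reports. "The series", "measured", "known", "first", "only" and "open" are said of these compounds alone.

Of the compounds shown here, two of a shared core have been measured. Compound 1 `CCOC(=O)/C=N/c1cnc(Nc2ccc(S(N)(=O)=O)cc2)nc1NC1CCCC1` gives 20700 nM in a functional assay on HeLa cells (Homo sapiens) for antiproliferative activity, read by MTT assay (on this read-out lower numbers stand for stronger inhibition and higher numbers for weaker inhibition), and compound 2 `CCOC(=O)/C=N/c1cnc(Nc2ccc(S(N)(=O)=O)cc2)nc1NC(C)C` gives 83300 nM. The step of a 4.0-fold higher number from compound 1 to compound 2 (0.60 log units; beyond the scatter) leaves compound 2 with the highest number of the two, its nearest neighbour being compound 1. Compound 3 `CC(C)Nc1nc(Nc2ccc(S(N)(=O)=O)cc2)ncc1/N=C/c1ccc(C(F)(F)F)cc1` has not been measured; it differs from compound 2 in that (4-(trifluoromethyl)phenyl in place of ethoxycarbonyl on a carbon with a double bond to nitrogen). Within the data shown here, the one measured step, from compound 1 to compound 2, concerns a different position and a different kind of group, so no measured step bears on this change, and its direction cannot be read from the data. The step of a 2.1-fold lower number from compound 2 to compound 3 (0.32 log units; beyond the scatter) is therefore expected to be uncertain, with a wide range allowed in either direction. Compound 3 is estimated at 40000 nM, between 8000 nM and 200000 nM.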

Compound 3, half-maximal inhibitory concentration: > 100000 nM
Compound 3: only a limit was reported (the forecaster's own chance of this, stated with the estimate: 20%); middle value at least 2.5-fold (0.39 log units) from the limit.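

For compound 3 in this assay, the reading is a limit and not a number: the limit of > 100000 nM in this assay, at which 1 of the 3 values shown sits. Among these compounds, the earlier compounds differed only in the group on the ring nitrogen, whereas the step of an at least 1.2-fold higher number from compound 2 to compound 3 (0.07 log units; that floor lies within the scatter) is the first change at the carbon with a double bond to nitrogen, and it shows that replacing ethoxycarbonyl with the larger 4-(trifluoromethyl)phenyl, which has an aromatic ring and no hydrogen-bond acceptors, brings no lower number. The floor of that step lies within the scatter, so the data fix neither its true size nor a real loss.

The compounds shown leave open whether a carboxylic acid or an unsubstituted phenyl on this carbon would give a lower number. They also leave open whether cyclopentyl on the nitrogen, paired with 4-(trifluoromethyl)phenyl, would bring the reading within the measurable range.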